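Triazole aryl variation: pentylphenyl to difluorophenyl

The source may hold more compounds than are shown below. What is called first, only, known or untested is meant among the compounds shown, and "the series" means these compounds.

For the measured compounds named here, compound 3 `CCCCCc1ccc(-c2cn(-c3cccc(C(=O)/C=C/c4ccc(O)c(OC)c4)c3)nn2)cc1` gives the lowest number of the three measured so far in a functional assay on RAW264.7 cells (Mus musculus) for inhibition, with a stated time of 4 days (a lower number here means a stronger inhibitor, a higher number a weaker inhibitor), at 5780 nM. Compound 1 `COc1cc(/C=C/C(=O)c2cccc(-n3cc(-c4ccccc4)nn3)c2)ccc1O` gives 16800 nM, and compound 2 `COc1cc(/C=C/C(=O)c2cccc(-n3cc(-c4ccc(F)cc4)nn3)c2)ccc1O` gives 6450 nM. One gap, a 1.1-fold lower number from compound 2 to compound 3 (0.05 log units; within the scatter), lies within the scatter, so those two cannot be ordered; the other gap, a 2.9-fold lower number from compound 1 to compound 3 (0.46 log units; beyond the scatter), is real.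

Compound 4 `COc1cc(/C=C/C(=O)c2cccc(-n3cc(-c4cc(F)cc(F)c4)nn3)c2)ccc1O` is made from compound 3 by 3,5-difluorophenyl in place of 4-pentylphenyl on an aromatic carbon. Going by the values given here, two measured steps bear on it: fluoro in place of hydrogen on an aromatic carbon, a 2.6-fold lower number from compound 1 to compound 2 (0.42 log units; beyond the scatter), and pentyl in place of hydrogen on an aromatic carbon, a 2.9-fold lower number from compound 1 to compound 3 (0.46 log units; beyond the scatter). Both aryl substituents lowered the number by a similar modest amount from the unsubstituted compound 1. Among the compounds with values here, no measured step places fluorine at the positions used in compound 4, so the effect of the second fluorine and of the changed placement is unknown. Since compound 2 and compound 3 sit within scatter of each other, compound 4 is expected to land near both, with a step of a 1.4-fold higher number from compound 3 to compound 4 (0.14 log units; within the scatter) in this assay. Compound 4 is thus estimated at 8000 nM, range 3500 nM to 18000 nM.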

Compound 4, half-maximal inhibitory concentration: 22800 nM
Beside the measured number, compound 4's estimate is 2.9-fold (0.45 log units) below it, outside the stated range (above it).
By their numbers in this assay, from the lowest: compounds 3 and 2 (each within the scatter of the next); then compounds 1 and 4 (each within the scatter of the next).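

In this assay this aryl position responds to more than the mere presence of a substituent, since moving to 3,5-difluorophenyl gives a 3.5-fold higher number from compound 2 to compound 4 (0.55 log units; beyond the scatter) from the 4-fluorophenyl group and a 3.9-fold higher number from compound 3 to compound 4 (0.60 log units; beyond the scatter) from the 4-pentylphenyl group. Substitution on this ring therefore does not lower the number in every case: compound 2 and compound 3 lie below compound 1, while the change to 3,5-difluorophenyl gives a 1.4-fold higher number from compound 1 to compound 4 (0.13 log units; within the scatter) and leaves compound 4 and compound 1 unordered. No supporting data account for this difference between the fluorinated groups.

The compounds shown leave open whether the second fluorine or the changed placement drives the higher number for compound 4. As far as these compounds go, how a chain longer than pentyl, an amine or a carboxylic acid on this aryl ring would read in this assay also remains open.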